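The compounds below may be only part of what the source reports. "The series", "measured", "known", "first", "only" and "open" are said of these compounds alone.

Compound 1 `O=C(/C(=C\c1ccc(O)c([N+](=O)[O-])c1)SCc1ccccc1Cl)c1ccc(Cl)cc1`: 10000 nM
Compound 2 `O=C(/C(=C\c1ccc(O)c([N+](=O)[O-])c1)SCc1ccc(Br)cc1)c1ccc(Cl)cc1Cl`: 10000 nM

Both values come from a functional assay on DU-145 cells (Homo sapiens) for inhibition, read by trypan blue exclusion, with a stated time of 96 h; on this read-out lower numbers stand for stronger inhibition of growth and higher numbers for weaker inhibition of growth. Compound 1 stands level with compound 2 at 10000 nM, with no difference beyond the usual scatter of repeated measurements. These two compounds differ in more than one place, so their values cannot show what any single change does.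

Compound 3 `O=C(/C(=C\c1ccc(O)c([N+](=O)[O-])c1)SCc1ccc(Br)cc1)c1ccc(C(F)(F)F)cc1` keeps the rest of compound 2 and changes one group: 4-(trifluoromethyl)phenyl in place of 2,4-dichlorophenyl on a carbonyl carbon. Put simply, 4-(trifluoromethyl)phenyl stands in place of 2,4-dichlorophenyl on a carbonyl carbon. Among the measured compounds shown here, no measured pair shows this exchange on its own, so the expectation rests on very little. For the measured compounds named here, the only guide is that two different structures give the same result, with compound 1 at 10000 nM and compound 2 at 10000 nM. On that basis, no step beyond the scatter is expected in this assay. The estimated change is a 1.3-fold lower number from compound 2 to compound 3 (0.10 log units; within the scatter). For compound 3 the expected value is 8000 nM, with an estimated range of 2500 nM to 15000 nM.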

Compound 3, concentration for 50% growth inhibition: 10000 nM
Estimate against measurement, compound 3: 1.3-fold (0.10 log units) below; measured number inside the range.
By their numbers in this assay, from the lowest: compounds 1, 2 and 3 (each within the scatter of the next).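

In this assay the exchange of 2,4-dichlorophenyl for 4-(trifluoromethyl)phenyl on a carbonyl carbon gives no change at the digits printed from compound 2 to compound 3 (within the scatter), and the rest of the molecule stays the same. Among the compounds shown here, compounds 2 and 3 are the first pair here that differ in one place, so this is the first direct reading of this position: a group of 10 heavy atoms with three fluorines replaces one of 8 heavy atoms with two chlorines, and the result in this growth test is the same at the digits printed. No measurement shown here offers an explanation for this match.

On these data alone, both groups are six-membered aromatic rings of carbon only, with no hydrogen-bond donors or acceptors, so it remains open whether a phenyl ring carrying an amine or a carboxylic acid on this carbonyl carbon would read differently. For the compounds shown here, this exchange is also seen in only one pair, so it remains open whether it would read the same with a different group elsewhere on the shared core.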